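Working notes: one more swap at the same aromatic position

The compounds below may be only part of what the source reports. "The series", "measured", "known", "first", "only" and "open" are said of these compounds alone.

Measured compounds, all in an ADME assay on Caco-2 cells (Homo sapiens) for permeability, in the apical to basolateral direction; on this read-out higher numbers stand for higher permeability and lower numbers for lower permeability:
compound 1, `CNC(=O)c1cc(Oc2ccc3oc(Nc4ccc(Br)cc4)nc3c2)ccn1`: 10 10^-6 cm/s
compound 2, `CCc1ccc(Nc2nc3cc(Oc4ccnc(C(=O)NC)c4)ccc3o2)cc1`: 10 10^-6 cm/s
compound 3, `CNC(=O)c1cc(Oc2ccc3oc(Nc4ccc(C(C)C)cc4)nc3c2)ccn1`: 10 10^-6 cm/s

Compound 3 stands level with compounds 1 and 2 in this assay; its nearest neighbour is compound 1 and its furthest is compound 2, and neither gap goes beyond the scatter. The three measured steps all sit at the same aromatic carbon: no change at the digits printed from compound 1 to compound 2 (within the scatter), no change at the digits printed from compound 1 to compound 3 (within the scatter) and no change at the digits printed from compound 2 to compound 3 (within the scatter). None of them moved the read-out at the digits printed.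

Compound 4, `CNC(=O)c1cc(Oc2ccc3oc(Nc4ccc(OC(F)(F)F)cc4)nc3c2)ccn1`, is not yet measured. It differs from compound 3 by trifluoromethoxy in place of isopropyl on an aromatic carbon. For the measured compounds named here, this group is new to the series, so no measured step covers it directly; the steps that bear on it are the three swaps at the same carbon, all of which stayed within the scatter. On that basis no step beyond the scatter is expected from compound 3 to compound 4 in this assay, so no change at the digits printed from compound 3 to compound 4 (within the scatter) is the estimated change. Compound 4 is therefore expected to give about 10 10^-6 cm/s, with a range from 5 10^-6 cm/s to 20 10^-6 cm/s. The actual measurement follows.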

Compound 4, apparent permeability: 10 10^-6 cm/s
For compound 4 middle estimate and measured number coincide at the digits printed; the measured number falls inside the stated range.
By their numbers in this assay, from the lowest: compounds 1, 2, 3 and 4 (each within the scatter of the next).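

In this assay, the aromatic carbon para to a large group now holds a group that carries oxygen and fluorine, with a hydrogen-bond acceptor that the departing isopropyl lacks, and the read-out shows no change at the digits printed from compound 3 to compound 4 (within the scatter) for this swap. The comparisons with the two earlier groups agree, showing no change at the digits printed from compound 2 to compound 4 (within the scatter) for trifluoromethoxy in place of ethyl and no change at the digits printed from compound 1 to compound 4 (within the scatter) for trifluoromethoxy in place of bromo, so the level now extends across four groups of differing atom content at this carbon and to a larger group of 5 heavy atoms. No supporting data are available to account for this flat read-out.

As far as these compounds go, whether the level persists with a carboxylic acid, an amine or a longer chain at this same carbon remains open. Also open, from the compounds shown here alone, is whether a change elsewhere, such as replacing the amide hydrogen or moving the trifluoromethoxy group to another carbon of the same ring, would shift the read-out in this assay beyond the scatter.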